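Amino in place of methyl: compound 2 to compound 3

A few compounds are considered here, and "the series" means these few. Any claim that something is new, unique, unknown or untested is made for them only; others in the source may bear on it.

Measured in an ADME assay on the whole organism (strain Sprague-Dawley) for pharmacokinetics, with Rattus norvegicus as the target, read by LC-MS, at a dose of 50 mg/kg by the oral route; a lower number here means less compound in the circulation, a higher number more compound in the circulation at the dose given:
compound 1 `CCOC(=O)C1=C[C@@H](OC(CC)CC)[C@H](NC(C)=O)[C@@H](N/C(N)=N\O)C1`: 270 nM
compound 2 `CCOC(=O)C1=C[C@@H](OC(CC)CC)[C@H](NC(C)=O)[C@@H](NC(C)=N)C1`: 566 nM

Of these two measured compounds, compound 2 stands highest at 566 nM. Compound 3 `CCOC(=O)C1=C[C@@H](OC(CC)CC)[C@H](NC(C)=O)[C@@H](NC(=N)N)C1`, not yet measured, differs from compound 2 by amino in place of methyl on a carbon with a double bond to nitrogen, with amino in place of methyl on a carbon with a double bond to nitrogen. For the measured compounds named here, only one measured step bears on this change: a 2.1-fold higher number from compound 1 to compound 2 (0.32 log units; beyond the scatter). Compound 1 also carries amino on that carbon and shows the lower number, 270 nM, but its group differs from that of compound 2 in more than this one change, so the guidance is indirect and rests on a single pair. A modest move to a lower number in this assay is therefore expected. The expected change is a 2.3-fold lower number from compound 2 to compound 3 (0.35 log units; beyond the scatter). For compound 3 the estimated value is 250 nM, with an expected range of 80 nM to 700 nM.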

Compound 3, maximal plasma concentration in the Rattus norvegicus assay: 282 nM
Beside the measured number, compound 3's estimate is 1.1-fold (0.05 log units) below it; the measured number falls inside the stated range.
By their numbers in the Rattus norvegicus assay, from the lowest: compounds 1, 3 and 2 (each within the scatter of the next, the first and the last beyond it).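

For the compounds shown here, in the Rattus norvegicus assay, the first one-place comparison on a carbon with a double bond to nitrogen gives a 2.0-fold lower number from compound 2 to compound 3 (0.30 log units; within the scatter), so amino in place of methyl at this position is not separated from the scatter, although the step lies right at its edge. The group on the amine nitrogen in compound 3 reads alike with the larger group carried by compound 1, a 1.0-fold higher number from compound 1 to compound 3 (0.02 log units; within the scatter), which leaves compound 3 within the scatter of both neighbours even though a 2.1-fold higher number from compound 1 to compound 2 (0.32 log units; beyond the scatter) is printed as beyond it. In a physicochemical assay for solubility, read by HPLC, in phosphate buffer, with a stated time of 20 min, at pH 9.0 (a higher number here means a more soluble compound, a lower number a less soluble compound), compound 2 gives > 50000000 nM as a limit of the assay. In the physicochemical assay compound 3 gives > 50000000 nM as a limit of the assay. In the physicochemical assay, the step for this same change cannot be read, as both compounds sit at the limit of the assay: the limit of > 50000000 nM in the physicochemical assay, at which 2 of the 2 values shown sit.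

From the compounds shown here alone, whether a longer chain in place of methyl on this carbon would move the maximal plasma concentration beyond the scatter remains open. Going by these compounds, how a carboxylic acid on the shared core would read in the Rattus norvegicus assay also remains open.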